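Chloro on the aromatic ring of compound 2: working notes

A few compounds are considered here, and "the series" means these few. Any claim that something is new, unique, unknown or untested is made for them only; others in the source may bear on it.

compound 1 `O=C(CCCCC(S)CCS)Nc1ccccc1Cl` gives 12.1%
compound 2 `O=C(CCCCC(CCSC(=O)c1ccccc1)SC(=O)c1ccccc1)Nc1ccccc1` gives "not active" (no number reported)

In a functional assay on NCI-H460 cells (Homo sapiens) for inhibition, read by MTT assay, with a stated time of 24 h, tested at 100 ug/mL (on this read-out lower numbers stand for less inhibition of growth and higher numbers for more inhibition of growth at the one concentration tested), compound 1 reads 12.1% as its value. Compound 2 has no single number and stands as "not active" (no number reported) on this read-out. Compound 3 `O=C(CCCCC(CCSC(=O)c1ccccc1)SC(=O)c1ccccc1)Nc1cccc(Cl)c1` is still unmeasured. Its structural change is chloro in place of hydrogen on an aromatic carbon with chloro in place of hydrogen on an aromatic carbon. For the measured compounds named here, no measured pair isolates this change. In this assay no step beyond the scatter is expected, so growth inhibition should remain low, as with compound 2 at "not active" (no number reported) in that test. The expected value for compound 3 is 6% with an estimated range of 0% to 20% for this measurement.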

Compound 3, percent growth inhibition at one concentration: "not active" (no number reported)
No number was reported for compound 3; no gap can be computed for the estimate.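

In this assay compound 2 gives "not active" (no number reported) and compound 3 gives "not active" (no number reported) so no step can be read between them. The compounds shown leave open whether phenyl to 3-chlorophenyl changes growth inhibition at all. No evidence bears on this result.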